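The compounds below may be only part of what the source reports. "The series", "measured", "known", "first", "only" and "open" are said of these compounds alone.

Compound 3 `C=C(C)c1csc(CN[C@@H]2C[C@H]3C[C@@H]([C@H]2C)C3(C)C)c1` is measured in an ADME assay on MDCK cells (Canis lupus familiaris) for cytotoxicity, read by microscopy, with a stated time of 48 h (a lower number here means that less compound is tolerated, a higher number that more compound is tolerated), where compound 3 gives 25000 nM. On that number compound 3 stands level with compound 1 `C[C@H]1[C@H](NCc2cccs2)C[C@H]2C[C@@H]1C2(C)C`, which in this assay gives 25000 nM, and the two together hold the highest of the three numbers. The third member, compound 2 `Cc1csc(CN[C@@H]2C[C@H]3C[C@@H]([C@H]2C)C3(C)C)c1`, gives 12500 nM in this assay, and the step of a 2.0-fold higher number from compound 2 to compound 3 (0.30 log units; within the scatter) keeps compound 3 within the scatter of compound 2 as well.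

The next compound is compound 4 `C[C@H]1[C@H](NCc2cc(C3CCCC3)cs2)C[C@H]2C[C@@H]1C2(C)C`. Its difference from compound 3 is cyclopentyl in place of 1-methylethenyl on an aromatic carbon.

Going by the values given here, three measured steps bear on this change, since each of them alters the same aromatic carbon. The step of no change at the digits printed from compound 1 to compound 3 (within the scatter) and the step of a 2.0-fold lower number from compound 1 to compound 2 (0.30 log units; within the scatter) show that adding a group at that carbon hardly moves the number, and the step of a 2.0-fold higher number from compound 2 to compound 3 (0.30 log units; within the scatter) shows the same for an exchange of one group for another. None of them leaves the scatter, so a further exchange at that carbon, here to cyclopentyl, is expected to give no step beyond the scatter in this assay.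

Compound 4 is therefore expected to give 20000 nM in this assay, within a range from 10000 nM to 40000 nM, an expected step of a 1.3-fold lower number from compound 3 to compound 4 (0.10 log units; within the scatter).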

Compound 4, minimum cytotoxic concentration: 1560 nM
Compound 4: middle estimate off by 13-fold (1.11 log units), on the high side; the whole stated range lies above it.
By their numbers in this assay, from the lowest: compound 4; then compounds 2, 1 and 3 (each within the scatter of the next).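

In this assay, going by these compounds alone, the earlier compounds made this aromatic carbon, two ring bonds from the ring sulfur, look tolerant of change, but cyclopentyl shows that it is not: the exchange gives a 16-fold lower number from compound 3 to compound 4 (1.20 log units; beyond the scatter) and, measured against the other two compounds, a 16-fold lower number from compound 1 to compound 4 (1.20 log units; beyond the scatter) and an 8.0-fold lower number from compound 2 to compound 4 (0.90 log units; beyond the scatter) in turn. Hydrogen, methyl and 1-methylethenyl at this carbon all stay within the scatter of one another, so only cyclopentyl, with its 5 heavy atoms and its five-membered non-aromatic ring of carbon only, separates from the rest, and less of compound 4 is tolerated than of any of the other three. No measurement shown here accounts for this difference.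

The compounds shown leave open whether the ring itself or the number of carbons goes with the lower number, a question that cyclopropyl, an open-chain pentyl group or phenyl at the same carbon would bear on. They also leave open how this carbon responds to groups that hold atoms other than carbon, such as an amine or a carboxylic acid.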